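This account rests on a few compounds, and the source may have more. Where it says the series, first, only, none or still open, it means among the compounds named here.

Measured compounds:
compound 1 `C=C(C)C(=O)c1ccc(OC)cc1OC` — 23.7%
compound 2 `COc1ccc(C2=NN(C(=O)NS(=O)(=O)c3ccc(Cl)cc3)CC2C)c(OC)c1` — 12.3%

In a functional assay on the whole organism (strain albino) for inhibition, with Rattus norvegicus as the target, read by paw edema, with stated times of 30 min and 1 h, at a dose of 25 mg/kg by the intraperitoneal route (on this read-out higher numbers stand for more inhibition at the one dose given (going by the name of the read-out) and lower numbers for less inhibition), compound 1 gives 23.7%, and compound 2 gives 12.3%. Compound 2 thus stands lowest of the two numbers; its nearest neighbour is compound 1, whose number is higher by a margin beyond the scatter. Compound 3 `COc1ccc(C2=NN(C(=O)NS(=O)(=O)c3ccc(C)cc3)CC2C)c(OC)c1` has not yet been measured. It differs from compound 2 in one place: methyl in place of chloro on an aromatic carbon. Going by the values given here, no pair of measured compounds shows this change, so nothing in the two numbers tells how much it is worth. Among the compounds with values here, with only a single reading available for the shared core of compound 2 and compound 3, the expected outcome is a step that stays within the scatter, in no preferred direction. The estimate for compound 3 is 14%, with a range from 2% to 28%. The step expected from this estimate is a number 1.7 percentage points higher from compound 2 to compound 3 (within the scatter).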

Compound 3, a percentage reported as inhibition, in the whole organism at one dose (the size of the read-out at that dose, not a potency): 23.7%
For compound 3 the middle estimate is 9.7 percentage points below the measured one, and the stated range covers the measured number.
By their numbers in this assay, from the lowest: compound 2; then compounds 1 and 3 (each within the scatter of the next).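

In this assay, replacing chloro with methyl on the aromatic carbon, the change from 4-chlorophenyl to 4-methylphenyl, gives a number 11.4 percentage points higher from compound 2 to compound 3 (beyond the scatter). Going by these compounds alone, this shows that the number responds to the group at this place, para to a large group, which the earlier compounds could not show, since no measured pair carried this change. The finding rests on this one pair, and nothing available bears on what lies behind the step.

The compounds shown leave open whether a methoxy group, an amine or a longer chain such as propyl at this place would raise the number further or bring it back towards that of compound 2. They also leave open whether the same change would give a step of similar size on another core.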